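Ortho-substituent swap on the phenyl-triazole amide series

This account rests on a few compounds, and the source may have more. Where it says the series, first, only, none or still open, it means among the compounds named here.

Within the data shown here, compound 2 `COc1ccccc1-n1cc(CN2C(=O)C[C@@H]3CC[C@@]2(C)C3(C)C)nn1` gives 120 nM in a functional assay on PANC-1 cells (Homo sapiens) for inhibition, read by MTT assay, with a stated time of 24 h (a higher number here means a weaker inhibitor, a lower number a stronger inhibitor), the lower of the two numbers measured so far; its only neighbour is compound 1 `CC1(C)[C@H]2CC[C@]1(C)N(Cc1cn(-c3ccccc3O)nn1)C(=O)C2`, which in this assay gives 230 nM, and the step of a 1.9-fold lower number from compound 1 to compound 2 (0.28 log units; within the scatter) stays within the scatter. Compound 3 `CC1(C)[C@H]2CC[C@]1(C)N(Cc1cn(-c3ccccc3C#N)nn1)C(=O)C2` differs from compound 2 by cyano in place of methoxy on an aromatic carbon. Among the measured compounds shown here, the one measured step, from compound 1 to compound 2, changes the same aromatic carbon and shows that a small change there leaves the number essentially where it was; no measured step involves a cyano group, so the effect of cyano in place of methoxy on an aromatic carbon is not anchored by any data. The expectation is therefore no step beyond the scatter. Compound 3 is expected to give 170 nM in this assay, in the range 60 nM to 500 nM, which means an expected step of a 1.4-fold higher number from compound 2 to compound 3 (0.15 log units; within the scatter).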

Compound 3, half-maximal inhibitory concentration: 240 nM
Compound 3: middle estimate off by 1.4-fold (0.15 log units), on the low side; the range from low to high includes it.
By their numbers in this assay, from the lowest: compounds 2, 1 and 3 (each within the scatter of the next).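

With cyano now measured, the aromatic carbon ortho to a large group has carried hydroxy, methoxy and cyano in this assay without any step leaving the scatter. The change of methoxy to cyano gives a 2.0-fold higher number from compound 2 to compound 3 (0.30 log units; within the scatter) and the change of hydroxy to cyano gives a 1.0-fold higher number from compound 1 to compound 3 (0.02 log units; within the scatter) so the cyano change now has measured steps from both earlier compounds. Across compounds 1, 2 and 3 the three groups at this carbon cannot be told apart in this assay, and no measured property accounts for the numbers here.

Still open, on these data alone, is whether an amine, a carboxylic acid or a longer chain such as butoxy on this carbon would give a step beyond the scatter. The compounds shown also leave open how these groups behave on any other carbon of the ring.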